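Shortening an Ethyl to a Methyl on Compound 1

This account rests on a few compounds, and the source may have more. Where it says the series, first, only, none or still open, it means among the compounds named here.

The compounds here share one core and are compared in a functional assay on MKN-45 cells (Homo sapiens) for antiproliferative activity, read by MTT assay, with a stated time of 72 h, tested at 10 uM; a higher number here means more inhibition at the concentration tested (going by the name of the read-out), a lower number less inhibition. Compound 1 `CCn1cc(-c2ccc(F)cc2)c(=O)c2c(Nc3ccc(Oc4ccnc(NC(=O)C5CC5)c4)c(F)c3)nccc21` gives 31.9%, the lowest of the three numbers. Compound 2 `CC(C)C(=O)Nc1cc(Oc2ccc(Nc3nccc4[nH]cc(-c5ccc(F)cc5)c(=O)c34)cc2F)ccn1` gives 95.4%, and compound 3 `Nc1nccc(Oc2ccc(Nc3nccc4[nH]cc(-c5ccc(F)cc5)c(=O)c34)cc2F)c1Cl` gives 85.7%; these two differ from compound 1 in more than one place, so their values only show that both lie far higher than compound 1, beyond the scatter. Going by the values given here, the one single-point step among the measured compounds, a number 9.7 percentage points lower from compound 2 to compound 3 (within the scatter), concerns a change on the oxygen-linked pyridine and not the part of the core altered here.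

Compound 4 `Cn1cc(-c2ccc(F)cc2)c(=O)c2c(Nc3ccc(Oc4ccnc(NC(=O)C5CC5)c4)c(F)c3)nccc21` is compound 1 with hydrogen in place of methyl on a saturated chain carbon bound to an aromatic nitrogen. Among the compounds with values here, no measured step touches this carbon, so the expectation rests on the change being small, the loss of one carbon, with nothing in the measured steps to suggest a large shift in either direction. The step from compound 1 to compound 4 is therefore expected to be modest, a number 13.1 percentage points higher from compound 1 to compound 4 (beyond the scatter), with wide uncertainty. Compound 4 is estimated at 45%, within a range from 15% to 80%.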

Compound 4, a percentage reported as inhibition, at one concentration (the size of the read-out at that concentration, not a potency): 30.9%
Compound 4: middle estimate off by 14.1 percentage points, on the high side; the measured number falls inside the stated range.
By their numbers in this assay, from the lowest: compounds 4 and 1 (each within the scatter of the next); then compounds 3 and 2 (each within the scatter of the next).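

In this assay, cutting the ethyl to a methyl gives a number 1 percentage points lower from compound 1 to compound 4 (within the scatter) and so leaves the read-out of the compound 1 series where it was: the loss of this one carbon cannot be told apart from the ordinary spread of repeated measurements. Going by these compounds alone, this is the first step that touches the chain on the aromatic nitrogen, since the earlier single-point step concerned only the oxygen-linked pyridine, and it shows that at this single tested concentration, shortening this chain from ethyl to methyl does not by itself move the inhibition beyond the scatter. Nothing in the available data explains why the two compounds read alike.

The compounds shown leave open whether a longer chain such as propyl, or a chain ending in an amine or a carboxylic acid, would read differently at this nitrogen. They also leave open whether the same change from ethyl to methyl would give so small a step in a compound carrying the 2-amino-3-chloropyridin-4-yl group.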